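The source may report more compounds than this note shows. Statements on the series, on what has been measured and on what is new or still open speak of the compounds shown alone.

Working notes on the series.

Compound 1 `Cc1ccc(NC(=S)N/N=C2\C(=O)Nc3ccc(F)cc32)cc1` is the parent. In a functional assay on MOLT-4 cells (Homo sapiens), with a stated time of 72 h (a lower number here means a stronger inhibitor, a higher number a weaker inhibitor), compound 1 gives 3000 nM. Compound 2 `Cc1ccc(NC(=S)N/N=C2\C(=O)N(Cc3ccc(F)cc3)c3ccc(F)cc32)cc1` carries a 4-fluorobenzyl in place of hydrogen on an amide-type nitrogen in a ring; in this assay compound 2 gives 1500 nM. Going by the values given here, the only step measured so far, a 2.0-fold lower number from compound 1 to compound 2 (0.30 log units; within the scatter), does not reach beyond the scatter, so compound 2 and compound 1 stand within the scatter of each other and neither is set apart on the numbers at hand.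

Compound 3 `Cc1ccc(NC(=S)N/N=C2\C(=O)N(Cc3ccc(F)cc3)c3ccc(Br)cc32)cc1` differs from compound 2 in one place: bromo in place of fluoro on an aromatic carbon of the fused ring system. Among the compounds with values here, no measured step touches that position; the single step recorded, from compound 1 to compound 2, concerns the amide-type nitrogen and so does not bear on this exchange. With nothing to anchor a shift in either direction, no step beyond the scatter is expected in this assay for compound 3, and the expected step is no change at the digits printed from compound 2 to compound 3 (within the scatter). For compound 3 the estimate in this assay is 1500 nM, with a range from 600 nM to 4000 nM.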

Compound 3, half-maximal inhibitory concentration: 57000 nM
Compound 3: middle estimate off by 38-fold (1.58 log units), on the low side; the measured number lies above the stated range.
By their numbers in this assay, from the lowest: compounds 2 and 1 (each within the scatter of the next); then compound 3.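

In this assay, the exchange of fluoro for bromo on an aromatic carbon of the fused system, with the 4-fluorobenzyl held in place, gives a 38-fold higher number from compound 2 to compound 3 (1.58 log units; beyond the scatter). Going by these compounds alone, this position is therefore sensitive to which halogen it carries, and it is the first place where a single change reaches beyond the scatter, whereas the change on the amide-type nitrogen, a 2.0-fold lower number from compound 1 to compound 2 (0.30 log units; within the scatter), did not. Fluoro and bromo have the same counts of heavy atoms, hydrogen-bond donors and hydrogen-bond acceptors, so those counts do not separate the two compounds, and no supporting data at hand explain the loss of activity.

The compounds shown leave open whether the loss is particular to bromo or extends to other replacements of fluoro at this position, such as chloro, hydrogen, methyl or an amine. They also leave open whether the bromo exchange has a step of similar size on the core of compound 1, with hydrogen rather than 4-fluorobenzyl on the amide-type nitrogen.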